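Swapping an Aryl Group for Thiophene on a Shared Core

This account rests on a few compounds, and the source may have more. Where it says the series, first, only, none or still open, it means among the compounds named here.

Measured so far:
- compound 1 `Brc1cn2ccnc2c(-c2ccc3ncn(C4CCCCC4)c3c2)n1`: 26.3%
- compound 2 `CC(=O)c1ccc(-c2cn3ccnc3c(-c3ccc4ncn(C5CCCCC5)c4c3)n2)cc1`: 14.3%
- compound 3 `COc1ccccc1-c1cn2ccnc2c(-c2ccc3ncn(C4CCCCC4)c3c2)n1`: 22.4%

Of the compounds shown here, three sharing one core have been tested in a functional assay on MOLT-4 cells (Homo sapiens) for inhibition, read by sulforhodamine B assay, with a stated time of 48 h, tested at 10 uM; a lower number here means less inhibition, a higher number more inhibition at the concentration tested (going by the name of the read-out). Compound 3 stands second highest of the three; its nearest neighbour is compound 1, and the gap between them is within the scatter, as is the gap to compound 2. Among the compounds with values here, the one step beyond the scatter is a number 12 percentage points lower from compound 1 to compound 2 (beyond the scatter), a modest drop.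

Compound 4 `c1csc(-c2cn3ccnc3c(-c3ccc4ncn(C5CCCCC5)c4c3)n2)c1` is the next member. The change from compound 3 is thiophen-2-yl in place of 2-methoxyphenyl on an aromatic carbon.

Within the data shown here, the steps that bear on this are the two other exchanges at the same position: a number 3.9 percentage points lower from compound 1 to compound 3 (within the scatter) and a number 8.1 percentage points higher from compound 2 to compound 3 (within the scatter), both within the scatter. Those steps suggest that exchanging the group at this position shifts the read-out only slightly, so the expected step is a number 0.4 percentage points lower from compound 3 to compound 4 (within the scatter), none beyond the scatter. Compound 4 is therefore estimated at 22%, with a range from 10% to 34%.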

Compound 4, a percentage reported as inhibition, at one concentration (the size of the read-out at that concentration, not a potency): 30.8%
For compound 4 the middle estimate is 8.8 percentage points below the measured one; the measured number falls inside the stated range.
By their numbers in this assay, from the lowest: compounds 2, 3, 1 and 4 (each within the scatter of the next, the first and the last beyond it).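

In this assay, thiophen-2-yl, the only five-membered aromatic ring with a hetero atom at this position, cannot be told apart from 2-methoxyphenyl (a number 8.4 percentage points higher from compound 3 to compound 4 (within the scatter)) or from bromo (a number 4.5 percentage points higher from compound 1 to compound 4 (within the scatter)). What is new is a second step beyond the scatter (a number 16.5 percentage points higher from compound 2 to compound 4 (beyond the scatter)), so compound 2 now stands apart from both compound 1 and compound 4, while compound 1, compound 3 and compound 4 stay within the scatter of one another. Nothing measured here tells why the numbers fall this way.

As far as these compounds go, with only four groups compared, it remains open whether the acetyl group itself sets compound 2 apart, which a plain phenyl at this position could help test. Also open, from the compounds shown here alone, is how a morpholine ring or a carboxylic acid at this position would read.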